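Swapping a Phenoxymethyl Tail for an Indole on a Crown Ester

The compounds below may be only part of what the source reports. "The series", "measured", "known", "first", "only" and "open" are said of these compounds alone.

Compound 1, `O=C(CCCCOc1ccccc1)OCC1COCCOCCOCCOCCOCCO1`: > 100000 nM
Compound 2, `O=C(OCC1COCCOCCOCCOCCOCCO1)c1cccc(-c2ccc(Br)cc2)c1`: 6400 nM
Compound 3, `O=C(CCCCC1CCCCC1)OCC1COCCOCCOCCOCCO1`: > 100000 nM

These three esters of a crown ether alcohol were tested in a functional assay on HBL-100 cells (Homo sapiens) for inhibition, read by sulforhodamine B assay, with a stated time of 48 h; a lower number here means a stronger inhibitor of growth, a higher number a weaker inhibitor of growth. For compound 1 the value > 100000 nM is a limit of the assay, not a number. Compound 3 likewise gives only the limit > 100000 nM. Compound 2 gives a measured number, 6400 nM. Compound 1 therefore stands at the limit of > 100000 nM in this assay, at which 2 of the 3 values shown sit. The new compound 4, `O=C(CCCc1cc2ccccc2[nH]1)OCC1COCCOCCOCCOCCOCCO1`, differs from compound 1 in one place: 1H-indol-2-yl in place of phenoxymethyl on a saturated chain carbon, three bonds along the chain from a carbonyl carbon. For the measured compounds named here, no measured pair shows this change, so its direction is open. Only a step toward stronger growth inhibition could turn the limit of compound 1 into a number. The expected step of an at least 1.2-fold lower number from compound 1 to compound 4 (0.09 log units; that floor lies within the scatter) is modest. Compound 4 is expected at 80000 nM, in the range 20000 nM to 300000 nM.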

Compound 4, concentration for 50% growth inhibition: > 100000 nM
Compound 4 ended at the assay's limit; the forecaster's own chance of this, stated with the estimate: 55%; at least 1.2-fold (0.09 log units) between middle value and limit.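

Compound 1 and compound 4 both sit at the limit of the assay, so no step can be read between them. On these data alone, whether 1H-indol-2-yl in place of phenoxymethyl changes growth inhibition at all, and in which direction, stays open.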